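The step from compound 3 to compound 4

The compounds below may be only part of what the source reports. "The series", "measured", "known", "first", "only" and "open" are said of these compounds alone.

Compound 1 `COCC1=C[C@@](C)(c2cc(NC(=O)c3ccc(C#N)cn3)ccc2F)N=C(N)O1`: 61%
Compound 2 `C[C@@]1(c2cc(NC(=O)c3coc(C(F)F)n3)ccc2F)C=C(CF)OC(N)=N1`: 57%
Compound 3 `C[C@@]1(c2cc(NC(=O)c3cnc(C(F)F)cn3)ccc2F)C=C(CF)OC(N)=N1`: 44%

These values come from an ADME assay on microsomes from liver (Rattus norvegicus, strain Crj;CD(SD)) for metabolic stability, read by LC-MS, using NADPH, with a stated time of 30 min, tested at 0.1 uM; on this read-out lower numbers stand for a less stable compound and higher numbers for a more stable compound. Compound 3 stands lowest of the three, and compound 1 and compound 2 both lie above it beyond the scatter. Compound 4 `C[C@@]1(c2cc(NC(=O)c3coc(CF)n3)ccc2F)C=C(CF)OC(N)=N1` carries 2-(fluoromethyl)-1,3-oxazol-4-yl in place of 5-(difluoromethyl)pyrazin-2-yl on a carbonyl carbon. Going by the values given here, one measured step bears on this: a number 13 percentage points lower from compound 2 to compound 3 (beyond the scatter), a modest one, with the exchange running the opposite way and with difluoromethyl on the oxazolyl group. Among the compounds with values here, no measured step shows the change from difluoromethyl to fluoromethyl. A modest rise in this assay is therefore expected, estimated as a number 11 percentage points higher from compound 3 to compound 4 (beyond the scatter). For compound 4 the estimated value is 55%, with an expected range from 41% to 69%.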

Compound 4, percent of the compound remaining: 39%
Beside the measured number, compound 4's estimate is 16 percentage points above it; measured number below the stated range.
By their numbers in this assay, from the lowest: compounds 4 and 3 (each within the scatter of the next); then compounds 2 and 1 (each within the scatter of the next).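

In this assay, the fluorine count on the chain of the oxazolyl group now has a measured effect on the number: hydrogen in place of one fluoro gives a modest drop (a number 18 percentage points lower from compound 2 to compound 4 (beyond the scatter)). The exchange of compound 3's pyrazinyl group for the fluoromethyl oxazolyl group does not separate the two compounds (a number 5 percentage points lower from compound 3 to compound 4 (within the scatter)). Nothing measured here accounts for these numbers. The compounds shown leave open how a plain methyl or a trifluoromethyl on the oxazolyl group would read. They also leave open whether fluoromethyl on the pyrazinyl group would give a similar step.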